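Swapping a Phenyl for Tert-Butyl on the Silicon

The source may report more compounds than this note shows. Statements on the series, on what has been measured and on what is new or still open speak of the compounds shown alone.

Measured so far:
Compound 1, `O=c1ccn(CCCO[Si](c2ccccc2)(c2ccccc2)c2ccccc2)c(=O)[nH]1`: 25000 nM
Compound 2, `O=c1ccn(CCCCCCO[Si](c2ccccc2)(c2ccccc2)c2ccccc2)c(=O)[nH]1`: 383000 nM

In an assay on isolated protein for inhibition of Deoxyuridine 5'-triphosphate nucleotidohydrolase, mitochondrial (Homo sapiens) (a higher number here means a weaker inhibitor, a lower number a stronger inhibitor), compound 1 gives 25000 nM. Compound 2 gives 383000 nM, the higher of the two numbers, reached by a 15-fold higher number from compound 1 to compound 2 (1.19 log units; beyond the scatter). Compound 3, `CC(C)(C)[Si](OCCCCCCn1ccc(=O)[nH]c1=O)(c1ccccc1)c1ccccc1`, differs from compound 2 by tert-butyl in place of phenyl on a silicon. Going by the values given here, no measured step touches the groups on the silicon, so the two numbers give no guide to this change. The step expected is none beyond the scatter, a 1.0-fold lower number from compound 2 to compound 3 (0.00 log units; within the scatter). Compound 3 is therefore estimated at 380000 nM, with a range from 130000 nM to 1100000 nM.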

Compound 3, inhibition constant: > 1000000 nM
Compound 3: no number, only a limit; the forecaster's own chance of this, stated with the estimate: 25%; middle value at least 2.6-fold (0.42 log units) from the limit.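

Compound 3 gives no true number in this assay, only a limit: the limit of > 1000000 nM in this assay, at which 1 of the 3 values shown sits. Even so, tert-butyl in place of phenyl on the silicon gives an at least 2.6-fold higher number from compound 2 to compound 3 (0.41 log units; beyond the scatter), so the groups on the silicon do affect the result, which the change in the chain between compound 1 and compound 2 could not show.

Going by these compounds, the full size of this step remains unknown. Also open, on these data alone, is whether tert-butyl has a similar effect in compound 1, and how methyl groups on the silicon would compare.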